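This account rests on a few compounds, and the source may have more. Where it says the series, first, only, none or still open, it means among the compounds named here.

Measured in a functional assay on HepG2 cells (Homo sapiens) for cytotoxicity, read by luminescence, with a stated time of 72 h; a lower number here means that less compound is needed, a higher number that more compound is needed for the effect:

- compound 1 `CN(Cc1cccc(F)c1)C(=O)c1cnc(-c2ccc(S(C)(=O)=O)c([N+](=O)[O-])c2)s1`: > 27000 nM
- compound 2 `CC1Cc2ccccc2N1C(=O)c1sc(-c2ccc(S(C)(=O)=O)c([N+](=O)[O-])c2)nc1C(F)(F)F`: > 27000 nM
- compound 3 `Cc1nc(-c2ccc(S(C)(=O)=O)c([N+](=O)[O-])c2)sc1C(=O)N1CCC(C)CC1`: > 27000 nM

Each of these entries is a limit and not a number. Compound 2 therefore has no exact standing among the three, and the shared position is the limit of > 27000 nM in this assay, at which 3 of the 3 values shown sit. Compound 4 `CS(=O)(=O)c1ccc(-c2nc(C(F)(F)F)c(C(=O)N3CCCCC3)s2)cc1[N+](=O)[O-]` carries piperidin-1-yl in place of 2-methyl-2,3-dihydro-1H-indol-1-yl on a carbonyl carbon. Among the compounds with values here, no measured step gives the size of such a change, so no step beyond the scatter is expected in this assay, in either direction. This expectation rests on compound 3, which also reads > 27000 nM. The expected step is a number no higher from compound 2 to compound 4 (the limit leaves the size open). For compound 4 the estimated value is 27000 nM, with an expected range of 15000 nM to 50000 nM.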

Compound 4, half-maximal effective concentration: > 27000 nM
Compound 4: no number, only a limit (the forecaster's own chance of this, stated with the estimate: 85%); the middle value lies on the limit itself.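

Compound 2 and compound 4 are both limits and not numbers in this assay, so no step can be read between them. The compounds shown leave open where any of their true values lies: the limit of > 27000 nM in this assay, at which 4 of the 4 values shown sit.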